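From Butyl to Phenyl on the Sulfonamide Nitrogen

The source may hold more compounds than are shown below. What is called first, only, known or untested is meant among the compounds shown, and "the series" means these compounds.

Compound 3 `CCCCNS(=O)(=O)c1ccc(Nc2ncc3c(n2)N(C2CCCC2)[C@H](CC)C(=O)N3C)cc1` stands lowest of the three measured compounds in a functional assay on A549 cells (Homo sapiens) for antiproliferative activity, read by CCK-8 assay, with a stated time of 72 h (a higher number here means a weaker inhibitor of growth, a lower number a stronger inhibitor of growth), at 477 nM. Compound 1 `CC[C@@H]1C(=O)N(C)c2cnc(Nc3ccc(S(N)(=O)=O)cc3)nc2N1C1CCCC1` gives 3390 nM in this assay, and compound 2 `CCC1C(=O)N(C)c2cnc(Nc3ccc(S(=O)(=O)NCCCO)cc3)nc2N1c1ccn(C)n1` gives 48900 nM. Within the data shown here, the one measured step that bears on this place is a 7.1-fold lower number from compound 1 to compound 3 (0.85 log units; beyond the scatter), a substituent taking the place of hydrogen on the same sulfonamide nitrogen. Compound 4 `CC[C@@H]1C(=O)N(C)c2cnc(Nc3ccc(S(=O)(=O)Nc4ccccc4)cc3)nc2N1C1CCCC1` differs from compound 3 by phenyl in place of butyl on a sulfonamide nitrogen. Among the measured compounds shown here, no measured pair shows one substituent traded for another at this place, so the step is expected to be a 1.0-fold higher number from compound 3 to compound 4 (0.02 log units; within the scatter), staying within the scatter in either direction. Compound 4 is accordingly estimated at 500 nM, with a range from 150 nM to 1800 nM.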

Compound 4, concentration for 50% growth inhibition: 4150 nM
Compound 4: middle estimate off by 8.3-fold (0.92 log units), on the low side, and the stated range ends below it.
By their numbers in this assay, from the lowest: compound 3; then compounds 1 and 4 (each within the scatter of the next); then compound 2.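

In this assay, phenyl in place of butyl on the sulfonamide nitrogen gives an 8.7-fold higher number from compound 3 to compound 4 (0.94 log units; beyond the scatter), while phenyl in place of hydrogen gives a 1.2-fold higher number from compound 1 to compound 4 (0.09 log units; within the scatter). The lower number of compound 3 therefore goes with butyl in particular, not with any substituent on that nitrogen, since phenyl leaves the number within the scatter of the unsubstituted sulfonamide. No evidence at hand accounts for this difference between butyl and phenyl. Open, going by these compounds, is how far the butyl result extends to other groups on this nitrogen: a propyl or hexyl chain, a benzyl group, or a butyl chain ending in an amine.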